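A few compounds are considered here, and "the series" means these few. Any claim that something is new, unique, unknown or untested is made for them only; others in the source may bear on it.

Measured in an ADME assay (Rattus norvegicus) for activation, read by fluorescence, with a stated time of 60 min, tested at 1 ug/mL; on this read-out lower numbers stand for lower permeability and higher numbers for higher permeability:
Compound 1 `CCCCCCCCOC(=O)CN(C)C(=N)N`: 0.93 10^-6 cm/s
Compound 2 `CCCCOC(=O)CN(C)C(=N)N`: 1.23 10^-6 cm/s

For the measured compounds named here, compound 2 gives 1.23 10^-6 cm/s, and compound 1, the only other compound measured, gives 0.93 10^-6 cm/s. These two values lie within the usual scatter of each other, so they cannot be ranked.

Compound 3 `CCCCCCCCCOC(=O)CN(C)C(=N)N` has not yet been measured. Its difference from compound 2 is pentyl in place of hydrogen on a saturated chain carbon, four bonds along the chain from an oxygen next to a carbonyl group.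

Going by the values given here, only one measured step touches this same place: a 1.3-fold higher number from compound 1 to compound 2 (0.12 log units; within the scatter), where hydrogen takes the place of butyl. That step lies within the scatter, so read in reverse, putting butyl on this carbon made no clear difference. It is a single step, and it involves butyl rather than pentyl, so it offers only thin guidance.

No step beyond the scatter is therefore expected in this assay. The estimated step is a 1.3-fold lower number from compound 2 to compound 3 (0.11 log units; within the scatter), which is expected to stay within the scatter. For compound 3 the estimated value is 0.95 10^-6 cm/s, with an expected range from 0.45 10^-6 cm/s to 2 10^-6 cm/s.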

Compound 3, apparent permeability: 1.49 10^-6 cm/s
Compound 3: middle estimate off by 1.6-fold (0.20 log units), on the low side; low and high end bracket the measured number.
By their numbers in this assay, from the lowest: compounds 1, 2 and 3 (each within the scatter of the next).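

In this assay, for the compounds shown here, pentyl in place of hydrogen on a saturated chain carbon, four bonds along the chain from an oxygen next to a carbonyl group, gives a 1.2-fold higher number from compound 2 to compound 3 (0.08 log units; within the scatter), so at this carbon pentyl, like butyl before it, produces no step that can be told from the scatter. The new compound also opens a second place: methyl in place of hydrogen on a saturated chain carbon, eight bonds along the chain from an oxygen next to a carbonyl group, gives a 1.6-fold higher number from compound 1 to compound 3 (0.20 log units; within the scatter), which again cannot be told from the scatter, so the three compounds still cannot be separated in this read-out. No measurement shown here offers an explanation for these small steps.

Going by these compounds, it remains open whether a much longer chain, such as hexadecyl, or a chain ending in an amine or a carboxylic acid, would give a step beyond the scatter at this carbon. Equally open, on these data alone, is what a short chain such as ethyl, or a phenyl ring in place of the chain, would do in this assay.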